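Methoxy for hydroxy on the hydrazone aryl ring

The source may report more compounds than this note shows. Statements on the series, on what has been measured and on what is new or still open speak of the compounds shown alone.

Measured so far:
Compound 1 `CSc1nn(-c2ccccc2)c2ncnc(N/N=C/c3cccc(O)c3)c12` gives 10.7 nM in a functional assay on MCF7 cells (Homo sapiens) for inhibition, read by sulforhodamine B assay, with a stated time of 48 h; on this read-out higher numbers stand for weaker inhibition and lower numbers for stronger inhibition.
Compound 2 `CSc1nn(-c2ccccc2)c2ncnc(N/N=C/c3ccc(O)cc3)c12` gives 10.3 nM in this assay.

Compound 2 and compound 1 sit within the usual scatter of each other, as the step of a 1.0-fold lower number from compound 1 to compound 2 (0.02 log units; within the scatter) shows. Compound 3 `COc1cccc(/C=N/Nc2ncnc3c2c(SC)nn3-c2ccccc2)c1` brings the change (3-methoxyphenyl in place of 4-hydroxyphenyl on a carbon with a double bond to nitrogen). For the measured compounds named here, the one measured step, moving the hydroxy group around the ring, changed little, but no measured pair shows what replacing the hydroxy group by a methoxy group does. A modest step is expected: a 1.7-fold higher number from compound 2 to compound 3 (0.24 log units; within the scatter). Compound 3 is therefore estimated at 18 nM, within 7 nM to 50 nM.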

Compound 3, half-maximal inhibitory concentration: 11.1 nM
Estimate against measurement, compound 3: 1.6-fold (0.21 log units) above; the measured number falls inside the stated range.
By their numbers in this assay, from the lowest: compounds 2, 1 and 3 (each within the scatter of the next).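

Methyl in place of hydrogen on the oxygen is the most direct comparison, and it leaves the two compounds within the scatter in this assay (a 1.0-fold higher number from compound 1 to compound 3 (0.02 log units; within the scatter)), as does the comparison with the 4-hydroxyphenyl compound (a 1.1-fold higher number from compound 2 to compound 3 (0.03 log units; within the scatter)). The hydroxy hydrogen, counted as the ring's one hydrogen-bond donor, is therefore not needed for a number in this range in this assay. Nothing measured here explains this result.

From the compounds shown here alone, whether an amine or a carboxylic acid on this ring would keep the number in this range remains open. So does the outcome for a longer chain on the oxygen.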